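Methoxy to Hydrogen on an Aromatic Ring: Expected Cytotoxicity

The compounds below may be only part of what the source reports. "The series", "measured", "known", "first", "only" and "open" are said of these compounds alone.

Compound 1 `C=CC1=C(C(=O)Nc2ccccc2OC)C(c2ccc(F)cc2)OC1` reaches only the limit of > 100000 nM in a functional assay on A549 cells (Homo sapiens) for cytotoxicity, read by MTT assay, with a stated time of 24 h; on this read-out lower numbers stand for stronger inhibition and higher numbers for weaker inhibition.
Compound 2 `C=CC1=C(C(=O)Nc2ccccc2)C(c2ccc(F)cc2)OC1` likewise reaches only the limit of > 100000 nM in this assay.
Compound 3 `C=CC1=C(C(=O)NCCC)C(c2ccc(OC)c(OC)c2)OC1` also reaches only the limit of > 100000 nM in this assay.

From compound 1 to compound 2 the change is hydrogen in place of methoxy on an aromatic carbon, and the step it made is a step that the two limits leave unreadable from compound 1 to compound 2. How the core of compound 3 differs from the core of compound 1 is not broken down here. Compound 4 `C=CC1=C(C(=O)NCCC)C(c2ccc(OC)cc2)OC1` differs from compound 3 by hydrogen in place of methoxy on an aromatic carbon, the same kind of change as that from compound 1 to compound 2, though the place differs: in compound 1 the methoxy sits ortho to a large group, in compound 3 it sits ortho to a methoxy group and meta to a large group. Because of the limit of > 100000 nM in this assay, at which 3 of the 3 values shown sit, no size can be read for the earlier step, and the expectation for compound 4 rests on that same limit. The step from compound 3 to compound 4 is expected to be a step that the limit leaves unreadable from compound 3 to compound 4. Compound 4 is therefore estimated at 150000 nM, between 50000 nM and 500000 nM, most likely again as a limit.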

Compound 4, half-maximal inhibitory concentration: > 100000 nM
Compound 4: a limit, no number; the forecaster's own chance of this, stated with the estimate: 85%; the middle value does not contradict the limit.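

Compound 4, like compound 3, stands only as a limit in this assay, so the change between them has no readable size and gives no new step: the limit of > 100000 nM in this assay, at which 4 of the 4 values shown sit.

The compounds shown leave open whether hydrogen in place of methoxy on an aromatic carbon alters the result in this assay at all, and what structure would give a readable number.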